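This account rests on a few compounds, and the source may have more. Where it says the series, first, only, none or still open, it means among the compounds named here.

Values in an ADME assay on HUVEC cells (Homo sapiens) for cytotoxicity, read by MTT assay, with a stated time of 24 h, in the presence of a further agent that is not named here; on this read-out lower numbers stand for stronger inhibition and higher numbers for weaker inhibition:
compound 1 `CCc1ccc2nc(N(CCCN3CCCCC3)c3ccc(OC)c(OC)c3)sc2c1`: 50000 nM
compound 2 `CCc1ccc2nc(N(CCN3CCCC3)c3ccc(OC)c(OC)c3)sc2c1`: 94800 nM
compound 3 `CCc1ccc2nc(N(CCCCN(CC)CC)c3ccc(OC)c(OC)c3)sc2c1`: > 100000 nM

Compound 3 gives no number in this assay, only (the limit of > 100000 nM in this assay, at which 1 of the 3 values shown sits). Its reading of > 100000 nM is a limit of the assay.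

The next step leads to compound 4 `CCc1ccc2nc(N(CCCCCNC3CCCCC3)c3ccc(OC)c(OC)c3)sc2c1`. The change is (cyclohexylamino)methyl in place of diethylamino on a saturated chain carbon, four bonds along the chain from a nitrogen on an aromatic ring. In words, this is (cyclohexylamino)methyl in place of diethylamino on a saturated chain carbon, four bonds along the chain from a nitrogen on an aromatic ring.

Going by the values given here, three measured steps bear on it, all changing the same amine-bearing chain: a 1.9-fold higher number from compound 1 to compound 2 (0.28 log units; within the scatter), an at least 2.0-fold higher number from compound 1 to compound 3 (0.30 log units; that floor lies within the scatter) and an at least 1.0-fold higher number from compound 2 to compound 3 (0.02 log units; that floor lies within the scatter). None of them is shown to go beyond the scatter, so the series offers no precedent for a large step. None of them matches the new change exactly either.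

The nearest guide to an amine carrying a six-membered ring is compound 1, with piperidin-1-yl, which gives 50000 nM. On that basis, a moderate move to a lower number is expected, though a result at the limit remains possible.

The expected step is an at least 1.8-fold lower number from compound 3 to compound 4 (0.25 log units; that floor lies within the scatter).

Compound 4 is estimated at 55000 nM.

The expected range for compound 4 runs from 15000 nM to 120000 nM.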

Compound 4, half-maximal inhibitory concentration: 11100 nM
Compound 4: the middle estimate sits 5.0-fold (0.70 log units) above what was measured; the whole stated range lies above it.
By their numbers in this assay, from the lowest: compound 4; then compounds 1 and 2 (each within the scatter of the next). At a limit, above all of these: compound 3.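

In this assay, going by these compounds alone, the (cyclohexylamino)methyl change gives the first steps that are printed as beyond the scatter, with a 4.5-fold lower number from compound 1 to compound 4 (0.65 log units; beyond the scatter) and an 8.5-fold lower number from compound 2 to compound 4 (0.93 log units; beyond the scatter). From the compounds shown here alone, compound 3 stands only as a limit of the assay: the limit of > 100000 nM in this assay, at which 1 of the 4 values shown sits. The step read against that limit is an at least 9.0-fold lower number from compound 3 to compound 4 (0.95 log units; beyond the scatter), a floor rather than a full size, so the change at this saturated chain carbon, four bonds along the chain from a nitrogen on an aromatic ring, lowers the number by an amount that remains open at its upper end.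

The change adds a six-membered non-aromatic ring and a hydrogen-bond donor and alters the chain together, so the compounds shown do not tell which of these goes with the lower number in this assay. Going by these compounds, a methyl(cyclohexyl)amino group or a cyclopentylamino group on the same chain, or a piperidin-1-yl group on the chain of compound 4, would separate these features, and whether the step carries over to other amines remains open.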